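From ethoxy to isopropoxy: compound 1 to compound 3

A few compounds are considered here, and "the series" means these few. Any claim that something is new, unique, unknown or untested is made for them only; others in the source may bear on it.

Compound 1 `CCO/C(O)=C1\C(C)=NC(C)=C([N+](=O)[O-])C1c1cccnc1` gives 8840 nM in a functional assay (cardiac atrium) for agonist activity, with Cavia porcellus as the target (on this read-out lower numbers stand for an effect already at smaller amounts and higher numbers for an effect only at larger amounts of compound), the lowest of the two numbers in hand. Compound 2 `CCO/C(O)=C1\C(C)=NC(C)=C([N+](=O)[O-])C1c1ccccn1` gives 22800 nM in this assay, and the step of a 2.6-fold higher number from compound 1 to compound 2 (0.41 log units; beyond the scatter) concerns pyridin-2-yl in place of pyridin-3-yl on a saturated ring carbon. Compound 3 `CC1=NC(C)=C([N+](=O)[O-])C(c2cccnc2)/C1=C(\O)OC(C)C` differs from compound 1 by methyl in place of hydrogen on a saturated chain carbon bound to an oxygen on an unsaturated carbon and a saturated chain carbon, ethoxy to isopropoxy. For the measured compounds named here, no measured step touches this position, so nothing in hand bears on the change. A step within the scatter is expected for a 1.1-fold lower number from compound 1 to compound 3 (0.04 log units; within the scatter). Compound 3 is estimated at 8000 nM, between 3000 nM and 25000 nM.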

Compound 3, half-maximal effective concentration: 28500 nM
Beside the measured number, compound 3's estimate is 3.6-fold (0.55 log units) below it; the whole stated range lies below it.
By their numbers in this assay, from the lowest: compound 1; then compounds 2 and 3 (each within the scatter of the next).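

In this assay, ethoxy to isopropoxy gives a 3.2-fold higher number from compound 1 to compound 3 (0.51 log units; beyond the scatter), so this position responds to the added methyl on the saturated chain carbon bound to the oxygen. With pyridin-3-yl held fixed, the branched isopropoxy is the less favourable of the two groups on this read-out. No available evidence bears on what lies behind this step.

From the compounds shown here alone, whether methoxy or a longer chain such as n-butoxy would give a lower or higher number remains open. So does whether the same change would give a similar step with pyridin-2-yl in place of pyridin-3-yl.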